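A few compounds are considered here, and "the series" means these few. Any claim that something is new, unique, unknown or untested is made for them only; others in the source may bear on it.

Measured compounds:
- compound 1 `C=CC(=O)Nc1cccc(NC(=O)CSc2nc(Nc3ccccc3)c3ccccc3n2)c1` — 8740 nM
- compound 2 `O=C(CSc1nc(Nc2ccccc2)c2ccccc2n1)Nc1ccc(Br)cc1` — 8450 nM

In a functional assay on PC-3 cells (Homo sapiens) for inhibition, read by MTT assay, with a stated time of 72 h (a higher number here means a weaker inhibitor, a lower number a stronger inhibitor), compound 1 gives the higher of the two numbers, but compound 2 with 8450 nM sits next to it, and the step of a 1.0-fold lower number from compound 1 to compound 2 (0.01 log units; within the scatter) lies within the scatter; the two values are therefore not separated. Compound 3 `C=CC(=O)Nc1cccc(NC(=O)CSc2nc(Nc3ccc(F)c(Cl)c3)c3ccccc3n2)c1` is unmeasured. Its change from compound 1 is 3-chloro-4-fluorophenyl in place of phenyl on a nitrogen on an aromatic ring. For the measured compounds named here, no measured step touches this part of the molecule: the only step available, the one from compound 1 to compound 2, alters the aryl on the amide-type nitrogen and is within the scatter, so it offers no guide to the anilino side. With nothing to go on, the expectation for this assay is a step of a 1.2-fold lower number from compound 1 to compound 3 (0.10 log units; within the scatter), not beyond the scatter, with a wide range. Compound 3 is thus estimated at 7000 nM, between 2500 nM and 20000 nM.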

Compound 3, half-maximal inhibitory concentration: > 50000 nM
Compound 3 ended at the assay's limit; the forecaster's own chance of this, stated with the estimate: 10%; middle value at least 7.1-fold (0.85 log units) away from the limit.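

In this assay, the anilino side proves sensitive in a way the amide side did not: changing anilino to (3-chloro-4-fluorophenyl)amino gives an at least 5.7-fold higher number from compound 1 to compound 3 (0.75 log units; beyond the scatter), whereas the aryl change on the amide-type nitrogen gave a 1.0-fold lower number from compound 1 to compound 2 (0.01 log units; within the scatter). Compound 3 gives > 50000 nM, which is a limit of the assay and not a number: the limit of > 50000 nM in this assay, at which 1 of the 3 values shown sits. The step therefore has a lower bound only, and this single pair shows that, on the core of compound 1, the position on that nitrogen does not tolerate every aryl group.

The compounds shown leave open whether chlorine or fluorine alone would carry this step, as in a 3-chlorophenyl or a 4-fluorophenyl on that nitrogen. Also open, from the compounds shown here alone, is whether the same change would have a comparable effect alongside the 4-bromophenyl of compound 2.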